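This account rests on a few compounds, and the source may have more. Where it says the series, first, only, none or still open, it means among the compounds named here.

Measured in a functional assay on the whole organism with Rattus norvegicus as the target, at a dose of 100 mg/kg; on this read-out higher numbers stand for more inhibition at the one dose given (going by the name of the read-out) and lower numbers for less inhibition:
compound 1, `C/N=C(\S)NCCCCCn1nc(-c2ccccc2)ccc1=O`, 68.9%
compound 2, `CC/N=C(\S)NCCCCCn1nc(-c2ccccc2)ccc1=O`, 66.4%
compound 3, `C/N=C(\S)NCCCn1nc(-c2ccccc2)ccc1=O`, 38.9%

Compound 3 gives the lowest of the three numbers in this assay. Its nearest neighbour is compound 2, with a gap of a number 27.5 percentage points lower from compound 2 to compound 3 (beyond the scatter), and the furthest gap is a number 30 percentage points lower from compound 1 to compound 3 (beyond the scatter), both beyond the scatter. Compound 4 is `N#CNC(=N)NCCCn1nc(-c2ccccc2)ccc1=O`. It differs from compound 3 in one place: a group of 5 heavy atoms (2 carbon, 3 nitrogen; no ring) in place of a group of 4 heavy atoms (2 carbon, 1 nitrogen, 1 sulfur; no ring), on an amine nitrogen. Neither measured step bears directly on this change: a number 2.5 percentage points lower from compound 1 to compound 2 (within the scatter) concerns a methyl on a saturated chain carbon bound to a double-bonded nitrogen, and a number 30 percentage points lower from compound 1 to compound 3 (beyond the scatter) concerns the length of the chain, whereas the sulfur-bearing group stays the same in every measured compound. With no guide to direction, no step beyond the scatter is assumed. Compound 4 is therefore expected to give about 36%, within 12% to 60%. The expected step is a number 2.9 percentage points lower from compound 3 to compound 4 (within the scatter), an estimate only.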

Compound 4, a percentage reported as inhibition, in the whole organism at one dose (the size of the read-out at that dose, not a potency): 33.3%
For compound 4 the middle estimate is 2.7 percentage points above the measured one; measured number inside the range.
By their numbers in this assay, from the lowest: compounds 4 and 3 (each within the scatter of the next); then compounds 2 and 1 (each within the scatter of the next).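

In this assay, a group of 5 heavy atoms without sulfur on the amine nitrogen, in place of the sulfur-bearing group of 4 heavy atoms, gives a number 5.6 percentage points lower from compound 3 to compound 4 (within the scatter), so sulfur in this group is not needed to keep this level of inhibition on the shorter chain. The wider steps, a number 33.1 percentage points lower from compound 2 to compound 4 (beyond the scatter) and a number 35.6 percentage points lower from compound 1 to compound 4 (beyond the scatter), combine this exchange with the change in the chain. No evidence is available to explain these results.

On these data alone, it remains open whether the sulfur-free group would behave alike on the longer chain of compound 1, and how an amine or a carboxylic acid would read on this amine nitrogen.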